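This account rests on a few compounds, and the source may have more. Where it says the series, first, only, none or still open, it means among the compounds named here.

Working notes on the series. Three compounds have numbers in an assay for positive allosteric modulation of metabotropic glutamate receptor 2 (Rattus norvegicus); a higher number here means that more compound is needed for the effect, a lower number that less compound is needed. Compound 1 `CNC(=O)c1cc(OCCCCOc2ccc(C(=O)CC(C)(C)C)c(O)c2C)ccc1F` gives 164 nM; compound 2 `Cc1c(OCCCCOc2ccc(C(=O)O)c(F)c2)ccc(C(=O)CC(C)(C)C)c1O` gives 80 nM; compound 3 `Cc1c(OCCCCOc2ccc(C(=O)O)cc2F)ccc(C(=O)CC(C)(C)C)c1O` gives 75 nM. Among the measured compounds shown here, compound 3 holds the lowest of the three numbers, but its nearest neighbour is within the scatter: the only single-point step measured, a 1.1-fold lower number from compound 2 to compound 3 (0.03 log units; within the scatter), is flat. The gap to compound 1, at about double, is beyond the scatter, though compound 1 differs from compound 3 in more than one place.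

Compound 4 `Cc1c(OCCCCOc2ccc(F)c(C(N)=O)c2)ccc(C(=O)CC(C)(C)C)c1O` is not yet measured. Relative to compound 3 the change is 3-carbamoyl-4-fluorophenyl in place of 4-carboxy-2-fluorophenyl on an oxygen on a saturated carbon. For the measured compounds named here, no measured step covers an acid-to-amide exchange on this ring, so only the values bear on it: the two acids, compound 2 and compound 3, sit close together, while compound 1, which also carries an amide on the distal ring, sits higher. A modest rise is therefore expected, a 1.7-fold higher number from compound 3 to compound 4 (0.24 log units; within the scatter), direction uncertain and of uncertain size. Compound 4 is estimated at 130 nM in this assay, within 60 nM to 300 nM.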

Compound 4, half-maximal effective concentration: > 10000 nM
Compound 4: a limit, no number; the forecaster's own chance of this, stated with the estimate: 5%; middle value at least 76-fold (1.88 log units) from the limit.
By their numbers in this assay, from the lowest: compounds 3 and 2 (each within the scatter of the next); then compound 1. At a limit, above all of these: compound 4.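

In this assay compound 4 gives > 10000 nM, which is a limit of the assay and not a number. The earlier acids suggested a tolerant distal ring, yet the 3-carbamoyl-4-fluorophenyl group brings a large rise from either acid (an at least 130-fold higher number from compound 3 to compound 4 (2.12 log units; beyond the scatter)) and (an at least 120-fold higher number from compound 2 to compound 4 (2.09 log units; beyond the scatter)). The sharpest reading lies at the amide itself, where hydrogen in place of methyl on an amide-type nitrogen is a single change, and it alone separates a measurable compound from a limit (an at least 60-fold higher number from compound 1 to compound 4 (1.78 log units; beyond the scatter)).

Since all three steps end at a limit, their true size stays unknown, and the compounds shown do not say whether the amide hydrogen or the missing methyl is what counts. An ethyl group or a second methyl on that nitrogen, or a carboxylic acid in place of the amide on this same ring, would separate these readings.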